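The compounds below may be only part of what the source reports. "The series", "measured", "known", "first", "only" and "open" are said of these compounds alone.

Three chains on the aromatic oxygen of a shared core have been run in a functional assay on BGC-823 cells (Homo sapiens) for cytotoxicity, read by MTT assay, with a stated time of 48 h (on this read-out higher numbers stand for weaker inhibition and lower numbers for stronger inhibition), so far. Compound 1 `CCCCCCOc1ccc2c(Cl)ccnc2c1` gives 2380 nM, compound 2 `CC(C)COc1ccc2c(Cl)ccnc2c1` gives 3030 nM, and compound 3 `CCOc1ccc2c(Cl)ccnc2c1` gives 3910 nM. Compound 3 carries the highest of the three numbers, yet a 1.6-fold higher number from compound 1 to compound 3 (0.22 log units; within the scatter) and a 1.3-fold higher number from compound 2 to compound 3 (0.11 log units; within the scatter) both sit within the scatter, as does a 1.3-fold higher number from compound 1 to compound 2 (0.10 log units; within the scatter); on these numbers the three chains are not told apart in this assay.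

Compound 4 `CC(C)Oc1ccc2c(Cl)ccnc2c1` differs from compound 3 by methyl in place of hydrogen on a saturated chain carbon bound to an oxygen on an aromatic ring and a saturated chain carbon. The step bearing most directly on this is a 1.3-fold higher number from compound 2 to compound 3 (0.11 log units; within the scatter), which runs the other way at the same saturated chain carbon bound to the aromatic oxygen, and a 1.3-fold higher number from compound 1 to compound 2 (0.10 log units; within the scatter) also reshaped the chain at that carbon; neither moved the number beyond the scatter. No step beyond the scatter is therefore expected for compound 4 in this assay, and the expected step is a 1.2-fold lower number from compound 3 to compound 4 (0.07 log units; within the scatter). Compound 4 is estimated at 3300 nM, with a range from 1800 nM to 6500 nM.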

Compound 4, half-maximal inhibitory concentration: 2630 nM
Compound 4: the middle estimate sits 1.3-fold (0.10 log units) above what was measured; low and high end bracket the measured number.
By their numbers in this assay, from the lowest: compounds 1, 4, 2 and 3 (each within the scatter of the next).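

In this assay, methyl on a saturated chain carbon bound to an oxygen on an aromatic ring, the change from ethoxy to isopropoxy, gives a 1.5-fold lower number from compound 3 to compound 4 (0.17 log units; within the scatter) and stays within the scatter, so branching directly at this carbon does not separate these two compounds. The isopropyl chain is likewise not told apart from the isobutyl chain (a 1.2-fold lower number from compound 2 to compound 4 (0.06 log units; within the scatter)) or the hexyl chain (a 1.1-fold higher number from compound 1 to compound 4 (0.04 log units; within the scatter)), which leaves all four chains on this oxygen unresolved, whether straight or branched and whichever carbon carries the branch. No supporting data bear on these small steps.

All the groups shown on this oxygen are plain saturated chains. Going by these compounds, whether a chain ending in an amine or a carboxylic acid, or a phenyl ring on this oxygen, would move the number beyond the scatter remains open.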